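The compounds below may be only part of what the source reports. "The series", "measured", "known", "first", "only" and "open" are said of these compounds alone.

Compound 1 `COC(=O)N1N=C(c2ccccc2)CC1c1cc(OC)c(OC)c(OC)c1` gives 2770 nM in a functional assay on A2780 cells (Homo sapiens) for antiproliferative activity, read by MTT assay, with a stated time of 48 h; on this read-out lower numbers stand for stronger inhibition of growth and higher numbers for weaker inhibition of growth. Compound 2 `CCCOC(=O)N1N=C(c2ccccc2)CC1c1cc(OC)c(OC)c(OC)c1` gives 10800 nM in this assay.

Compound 1 stands lowest of the two numbers, the only other lying at a 3.9-fold higher number from compound 1 to compound 2 (0.59 log units; beyond the scatter). Compound 3 `COC(=O)N1N=C(c2ccc(OC)c(OC)c2)CC1c1cc(OC)c(OC)c(OC)c1` differs from compound 1 in one place: 3,4-dimethoxyphenyl in place of phenyl on a carbon with a double bond to nitrogen. For the measured compounds named here, the single measured step concerns the ester chain on the carbamate, not the ring on the carbon with a double bond to nitrogen, so no measured step bears on this change. With nothing to guide a direction, compound 3 is expected to show no step beyond the scatter, estimated at 2500 nM with a range of 700 nM to 9000 nM. That estimate corresponds to a 1.1-fold lower number from compound 1 to compound 3 (0.04 log units; within the scatter).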

Compound 3, concentration for 50% growth inhibition: 11400 nM
For compound 3 the middle estimate is 4.6-fold (0.66 log units) below the measured one; measured number above the stated range.
By their numbers in this assay, from the lowest: compound 1; then compounds 2 and 3 (each within the scatter of the next).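

For the compounds shown here, this is the first measured change on the carbon with a double bond to nitrogen, and it shows that the group held there matters in this assay: 3,4-dimethoxyphenyl in place of phenyl gives a 4.1-fold higher number from compound 1 to compound 3 (0.61 log units; beyond the scatter). Of the two groups shown at this position on the shared core, phenyl goes with the stronger inhibition of growth. Nothing measured here accounts for this step.

From the compounds shown here alone, it remains open how a single methoxy group, a fluorine or a hydroxyl group on the phenyl would compare. Going by these compounds, it is also open whether the step would hold with the longer ester chain of compound 2.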